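The source may report more compounds than this note shows. Statements on the series, on what has been measured and on what is new or still open speak of the compounds shown alone.

Among the measured compounds shown here, in a functional assay on A549 cells (Homo sapiens) for antiproliferative activity, read by MTT assay, with a stated time of 72 h (a lower number here means a stronger inhibitor, a higher number a weaker inhibitor), compound 1 `COc1cccc(N2C(=O)COc3ccc(-c4cnc(Cl)c(NS(=O)(=O)c5ccc(F)cc5)c4)cc32)c1` gives 32700 nM, the only numeric value so far. Compound 2 `COc1ccc(N2C(=O)COc3ccc(-c4ccc(O)cc4)cc32)cc1` reports only a limit of the assay, > 40000 nM. Compound 3 `COc1ccc(N2C(=O)COc3ccc(-c4cnc(Cl)c(NS(=O)(=O)c5ccc(F)cc5)c4)cc32)cc1` carries 4-methoxyphenyl in place of 3-methoxyphenyl on an amide-type nitrogen in a ring. For the measured compounds named here, no measured pair shows this change, so the expectation in this assay rests on compound 1 at 32700 nM, with no step beyond the scatter in either direction. The expected step is a 1.1-fold lower number from compound 1 to compound 3 (0.04 log units; within the scatter). The estimate for compound 3 is 30000 nM, with an expected range of 14000 nM to 40000 nM.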

Compound 3, half-maximal inhibitory concentration: 30400 nM
Estimate against measurement, compound 3: 1.0-fold (0.01 log units) below; measured number inside the range.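

In this assay, among the compounds shown here, the only pair at this position gives a 1.1-fold lower number from compound 1 to compound 3 (0.03 log units; within the scatter), so 3-methoxyphenyl and 4-methoxyphenyl on the amide-type nitrogen in a ring cannot be told apart on this read-out. Moving the methoxy group around this phenyl ring therefore shifts nothing measurable in this pair. Compound 2 adds a limit, not a number: the limit of > 40000 nM in this assay, at which 1 of the 3 values shown sits.

Still open, on these data alone, is whether an amine or a carboxylic acid on this phenyl ring would give a step beyond the scatter. As far as these compounds go, whether the same holds with another core also remains open.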